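From Fluoro to Methoxy: Estimating Compound 3

The source may hold more compounds than are shown below. What is called first, only, known or untested is meant among the compounds shown, and "the series" means these compounds.

Compound 1, `Cc1ccccc1-c1cc(C#Cc2ccc(CCC(=O)O)cc2)ccn1`, gives 1070 nM in an in vitro functional assay on 1321-N1 cells for agonist activity at Free fatty acid receptor 1 (Homo sapiens), read by fluorescence, spectrophotometry and calcium flux; on this read-out lower numbers stand for an effect already at smaller amounts and higher numbers for an effect only at larger amounts of compound.
Compound 2, `O=C(O)CCc1ccc(C#Cc2ccnc(F)c2)cc1`, gives 513 nM in this assay.

Going by the values given here, compound 2 holds the lower of the two numbers measured so far; its only neighbour is compound 1, and the single measured step, a 2.1-fold lower number from compound 1 to compound 2 (0.32 log units; beyond the scatter), separates the two and lies beyond the scatter.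

Compound 3, `COc1cc(C#Cc2ccc(CCC(=O)O)cc2)ccn1`, has not been measured. It differs from compound 2 by methoxy in place of fluoro on an aromatic carbon, on an aromatic carbon of a six-membered aromatic ring with 1 nitrogen, next to the ring nitrogen. Among the compounds with values here, the one step that bears on this position, a 2.1-fold lower number from compound 1 to compound 2 (0.32 log units; beyond the scatter), replaced 2-methylphenyl with fluoro; no measured pair shows methoxy at this carbon, so the direction of the change is not anchored by the data. Compound 3 is therefore estimated at 700 nM, with a range from 250 nM to 2000 nM. The step this implies, a 1.4-fold higher number from compound 2 to compound 3 (0.13 log units; within the scatter), is expected to be small and may well remain within the scatter.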

Compound 3, half-maximal effective concentration: 525 nM
The estimate for compound 3 lay 1.3-fold (0.12 log units) above the measured number; the measured number falls inside the stated range.
By their numbers in this assay, from the lowest: compounds 2 and 3 (each within the scatter of the next); then compound 1.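

At the aromatic carbon next to the ring nitrogen, the compounds now include a measured pair with methoxy, and in this assay the exchange of fluoro for methoxy gives a 1.0-fold higher number from compound 2 to compound 3 (0.01 log units; within the scatter) and leaves the two groups indistinguishable on this read-out. Replacing 2-methylphenyl with methoxy gives a 2.0-fold lower number from compound 1 to compound 3 (0.31 log units; beyond the scatter) in the same assay, so the step first seen with fluoro is no longer tied to that one group: two different replacements of 2-methylphenyl now stand within the scatter of each other and apart from compound 1. No measurement offered here accounts for why fluoro and methoxy read alike at this carbon.

The compounds shown hold only fluoro, methoxy and 2-methylphenyl at this position, so it remains open whether an amine, a hydroxyl group or a longer alkoxy chain such as ethoxy would also fall with compound 2 and compound 3 or would stand apart from them. Also open, from the compounds shown here alone, is how far this picture would survive an amide in place of the carboxylic acid on the shared core.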